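Methylsulfanyl for methoxy in the fused-ring series

The source may hold more compounds than are shown below. What is called first, only, known or untested is meant among the compounds shown, and "the series" means these compounds.

Working notes. In a functional assay on the whole organism for inhibition, with Chenopodium ficifolium as the target, with a stated time of 72 h, tested at 10 mg/L (a higher number here means more inhibition of growth at the concentration tested, a lower number less inhibition of growth), compound 1 `COc1cc(C)nc2n/c(=N/C(=O)c3c(-c4ccc(Cl)cc4Cl)noc3C)sn12` gives 45.7%, the highest of the three numbers measured. Compound 3 `COc1cc(OC)n2s/c(=N\C(=O)c3c(-c4ccc(Cl)cc4Cl)noc3C)nc2n1` gives 28.9% in this assay, the step of a number 16.8 percentage points lower from compound 1 to compound 3 (beyond the scatter). Compound 2 `COc1cc(Cl)nc(NC(=S)NC(=O)c2c(-c3ccc(Cl)cc3Cl)noc2C)n1` gives 21.9%, and the two values of compound 1 and compound 2 lie further apart than those of compound 1 and compound 3. Compound 4 `CSc1cc(C)nc2n/c(=N/C(=O)c3c(-c4ccc(Cl)cc4Cl)noc3C)sn12` carries the change (methylsulfanyl in place of methoxy on an aromatic carbon). For the measured compounds named here, no measured step touches this exchange; the only step recorded, from compound 1 to compound 3, concerns a different exchange. The expectation is therefore a step of no clear direction beyond the scatter, estimated as a number 3.7 percentage points lower from compound 1 to compound 4 (within the scatter). Compound 4 is expected to give 42% in this assay, within 25% to 60%.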

Compound 4, percent growth inhibition at one concentration: 21.9%
Beside the measured number, compound 4's estimate is 20.1 percentage points above it; measured number outside the range, below it.
By their numbers in this assay, from the lowest: compounds 2, 4 and 3 (each within the scatter of the next); then compound 1.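

In this assay, methylsulfanyl in place of methoxy on the aromatic carbon next to the ring nitrogen gives a number 23.8 percentage points lower from compound 1 to compound 4 (beyond the scatter) with the count of heavy atoms, donors and acceptors unchanged. For the compounds shown here, this is the first reading at this position, since the earlier step concerned a different exchange, and it shows that the number responds to swapping oxygen for sulfur alone. Nothing available explains the drop.

With only methoxy and methylsulfanyl shown here, an amine, an ethoxy group or a chlorine at this position remains open. Going by these compounds, whether a longer chain on the sulfur would restore the number also stays open.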